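Chain on the amino nitrogen: branched alkyl to tert-butyl ester

A few compounds are considered here, and "the series" means these few. Any claim that something is new, unique, unknown or untested is made for them only; others in the source may bear on it.

Of the compounds shown here, three built on one shared core have been measured. Compound 1 `CCCCCNc1oc2c(C)ncc(CO)c2c1Nc1cccc([N+](=O)[O-])c1` gives 850 nM in a functional assay on HEK293 cells for agonist activity at Toll-like receptor 8 (Homo sapiens), read by reporter gene assay; a lower number here means that less compound is needed, a higher number that more compound is needed for the effect. Compound 2 `CCCCCNc1oc2c(C)ncc(CO)c2c1Nc1cccc(F)c1` gives 370 nM in this assay. Compound 3 `CCCC(C)Nc1oc2c(C)ncc(CO)c2c1Nc1ccccn1` gives 9010 nM in this assay, the highest of the three numbers; its gap to compound 1 and its wider gap to compound 2 both lie beyond the scatter, so compound 3 is the weakest agonist of the set.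

Among the compounds with values here, only one pair differs in a single place: a 2.3-fold lower number from compound 1 to compound 2 (0.36 log units; beyond the scatter), a fluoro in place of nitro on an aromatic carbon of the aryl amine. Compound 4 `Cc1ncc(CO)c2c(Nc3ccccn3)c(NCCC(=O)OC(C)(C)C)oc12` differs from compound 3 elsewhere, namely (2-(tert-butoxycarbonyl)ethyl in place of 1-methylbutyl on a nitrogen on an aromatic ring). Within the data shown here, no measured step touches this nitrogen or its chain, so the step from compound 1 to compound 2 does not bear on the change and gives no direction. The only footing is the weak activity of compound 3 itself.

Compound 4 is therefore expected near the value of compound 3, with a 1.3-fold higher number from compound 3 to compound 4 (0.12 log units; within the scatter) as the estimated step, in either direction or none beyond the scatter. The estimate for compound 4 is 12000 nM, within a range from 3000 nM to 50000 nM.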

Compound 4, half-maximal effective concentration: 7640 nM
Estimate against measurement, compound 4: 1.6-fold (0.20 log units) above, and the stated range covers the measured number.
By their numbers in this assay, from the lowest: compound 2; then compound 1; then compounds 4 and 3 (each within the scatter of the next).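

Within the data shown here, at the nitrogen on an aromatic ring, the first measured change in this assay is 2-(tert-butoxycarbonyl)ethyl in place of 1-methylbutyl, which gives a 1.2-fold lower number from compound 3 to compound 4 (0.07 log units; within the scatter). The entering chain has 9 heavy atoms against 5, and 2 hydrogen-bond acceptors against 0, so on the core of compound 3 these differences in chain make no difference beyond the scatter, and a branched alkyl chain and a chain ending in a tert-butyl ester cannot be told apart by this read-out. Nothing available explains why the two chains read alike.

From the compounds shown here alone, this finding rests on a single pair and applies only to the pyridinyl-type amine substituent shared by compound 3 and compound 4, so whether the same exchange would also leave the number within the scatter on the fluoro-bearing aryl amine of compound 2 remains open. Also open, going by these compounds, is how this position would read with a free carboxylic acid in place of the tert-butyl ester, with a primary amine at the end of the chain, or with a longer unbranched alkyl chain on this core.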